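Compound 3 to compound 4: one group made smaller

The source may hold more compounds than are shown below. What is called first, only, known or untested is meant among the compounds shown, and "the series" means these compounds.

In a physicochemical assay for solubility, read by spectrophotometry, in phosphate buffer, with a stated time of 2 h, at pH 7.4 (a higher number here means a more soluble compound, a lower number a less soluble compound), three compounds sharing one core have been measured. Compound 1 `COc1ccc2[nH]c(C(=O)N3CC(=O)N(Cc4ccccc4)[C@@H](COc4ccccc4)C3)cc2c1` gives 12200 nM, compound 2 `COc1ccc2[nH]c(C(=O)N3CC(=O)N(Cc4ccccc4)[C@@H](CN4CCC(C(C)C)CC4)C3)cc2c1` gives 12000 nM, and compound 3 `COc1ccc2[nH]c(C(=O)N3CC(=O)N(Cc4ccccc4)[C@@H](CN4CC5CCCCC5C4)C3)cc2c1` gives 23800 nM. Compound 3 thus lies within the scatter of both others, and the three numbers do not separate.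

Compound 4 `COc1ccc2[nH]c(C(=O)N3CC(=O)N(Cc4ccccc4)[C@@H](CN4CC5CC5C4)C3)cc2c1` differs from compound 3 in one place, on a saturated chain carbon bound to a saturated ring carbon: a group of 6 heavy atoms (5 carbon, 1 nitrogen; one three-membered non-aromatic ring of carbon only, one five-membered non-aromatic ring with 1 hetero atom) in place of a group of 9 heavy atoms (8 carbon, 1 nitrogen; one five-membered non-aromatic ring with 1 hetero atom, one six-membered non-aromatic ring of carbon only), on a saturated chain carbon bound to a saturated ring carbon. Three measured steps at this same place bear on the change: a 1.0-fold lower number from compound 1 to compound 2 (0.01 log units; within the scatter), a 2.0-fold higher number from compound 1 to compound 3 (0.29 log units; within the scatter) and a 2.0-fold higher number from compound 2 to compound 3 (0.30 log units; within the scatter). Among the compounds with values here, each stays within the scatter, although none of the measured groups has the three-membered ring of carbon only, so the evidence is indirect. No step beyond the scatter is therefore expected in this assay, in either direction. The expected size is a 1.1-fold higher number from compound 3 to compound 4 (0.02 log units; within the scatter). For compound 4 the estimated solubility is 25000 nM, with an expected range of 11000 nM to 55000 nM.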

Compound 4, solubility: 17500 nM
Beside the measured number, compound 4's estimate is 1.4-fold (0.15 log units) above it; the measured number falls inside the stated range.
By their numbers in this assay, from the lowest: compounds 2, 1, 4 and 3 (each within the scatter of the next).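

At the saturated chain carbon bound to a saturated ring carbon, a three-membered ring of carbon only now joins the groups compared, and in this assay every step to it stays within the scatter: a 1.4-fold lower number from compound 3 to compound 4 (0.13 log units; within the scatter), a 1.5-fold higher number from compound 2 to compound 4 (0.16 log units; within the scatter) and a 1.4-fold higher number from compound 1 to compound 4 (0.16 log units; within the scatter). A group of 6 heavy atoms thus does not separate from the groups of 7 and 9 heavy atoms, so group size over this span shows no link to the read-out across these four compounds. Nothing shown gives a measured reason for these numbers.

The compounds shown leave open whether any group at this place could produce a step beyond the scatter, for instance a carboxylic acid or a primary amine. They also leave open whether a change elsewhere on the shared core would do so.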